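Shortening the Ether Tail to a Piperidine

A few compounds are considered here, and "the series" means these few. Any claim that something is new, unique, unknown or untested is made for them only; others in the source may bear on it.

Compound 1 `c1cc([C@H]2CC[C@]3(CC2)OOC2(O3)C3CC4CC(C3)CC2C4)ccc1OCCCNC1CCOCC1` gives 10 mL.min-1.g-1 in an ADME assay on microsomes from liver (Homo sapiens) for metabolic stability, read by LC-MS, tested at 1 uM; on this read-out higher numbers stand for fast clearance and lower numbers for slow clearance.
Compound 2 `NCCS(=O)(=O)CCOc1ccc([C@H]2CC[C@]3(CC2)OOC2(O3)C3CC4CC(C3)CC2C4)cc1` gives 9 mL.min-1.g-1 in this assay.

Compound 1 stands highest of the two numbers, yet the step of a 1.1-fold lower number from compound 1 to compound 2 (0.05 log units; within the scatter) lies within the scatter. Compound 3 `c1cc([C@H]2CC[C@]3(CC2)OOC2(O3)C3CC4CC(C3)CC2C4)ccc1OCC1CCNCC1` differs from compound 1 in one place: piperidin-4-yl in place of 2-((oxan-4-yl)amino)ethyl on a saturated chain carbon bound to an oxygen on an aromatic ring. For the measured compounds named here, no measured step mirrors this change; the only available step exchanged a different tail at the far end of the chain and barely moved. The step of a 1.3-fold lower number from compound 1 to compound 3 (0.10 log units; within the scatter) is therefore expected to stay within the scatter. Compound 3 is estimated at 8 mL.min-1.g-1 in this assay, ranging from 4 mL.min-1.g-1 to 16 mL.min-1.g-1.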

Compound 3, intrinsic clearance in microsomes: < 7 mL.min-1.g-1
Compound 3 was reported as a limit; the forecaster's own chance of this, stated with the estimate: 5%; middle value at least 1.1-fold (0.05 log units) away from the limit.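

Compound 3, carrying piperidin-4-yl on a saturated chain carbon bound to an oxygen on an aromatic ring, is reported only as a limit: the limit of < 7 mL.min-1.g-1 in this assay, at which 1 of the 3 values shown sits. The change gives an at least 1.4-fold lower number from compound 1 to compound 3 (0.15 log units; that floor lies within the scatter), and the comparison with the (2-aminoethyl)sulfonyl tail gives an at least 1.2-fold lower number from compound 2 to compound 3 (0.10 log units; that floor lies within the scatter). Unlike the earlier pair, this place therefore shows a floor rather than a measured step, and neither floor reaches beyond the scatter.

On these data alone, how far the true number of compound 3 lies from its limit stays open. So does whether a longer chain carrying the piperidin-4-yl, or a carboxylic acid at this place, would behave alike.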